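This account rests on a few compounds, and the source may have more. Where it says the series, first, only, none or still open, it means among the compounds named here.

Of the compounds shown here, three sharing one core have been measured in a functional assay on MCF7 cells (Homo sapiens) for inhibition, read by sulforhodamine B assay, with a stated time of 48 h; a lower number here means a stronger inhibitor of growth, a higher number a weaker inhibitor of growth. Compound 1 `O=C(Cc1csc2nc(-c3ccc(Br)cc3)cn12)N/N=C/c1ccccc1` gives 75900 nM, compound 2 `O=C(Cc1csc2nc(-c3ccc(Br)cc3)cn12)N/N=C/c1ccccc1O` gives 13200 nM, and compound 3 `O=C(Cc1csc2nc(-c3ccc(Br)cc3)cn12)N/N=C/c1ccc(O)cc1` gives 63100 nM. Among these values, compound 3 stands apart only from compound 2. The two steps that place it are a 1.2-fold lower number from compound 1 to compound 3 (0.08 log units; within the scatter) and a 4.8-fold higher number from compound 2 to compound 3 (0.68 log units; beyond the scatter).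

Compound 4 `COc1cccc(OC)c1/C=N/NC(=O)Cc1csc2nc(-c3ccc(Br)cc3)cn12` carries 2,6-dimethoxyphenyl in place of 4-hydroxyphenyl on a carbon with a double bond to nitrogen. Going by the values given here, no measured step introduces a methoxy group, so the evidence here is indirect. The nearest guidance comes from the hydroxy changes on the same aromatic ring. Among the compounds with values here, compound 2 supplies the only such step beyond the scatter, a 5.8-fold lower number from compound 1 to compound 2 (0.76 log units; beyond the scatter), while compound 3 supplies one within it, a 1.2-fold lower number from compound 1 to compound 3 (0.08 log units; within the scatter). The swap between the two hydroxy compounds, a 4.8-fold higher number from compound 2 to compound 3 (0.68 log units; beyond the scatter), sets a modest scale for changes at this ring. In this assay, a step of no more than that modest size is therefore expected, most likely within the scatter and leaning slightly towards a lower number. The expected change is a 1.6-fold lower number from compound 3 to compound 4 (0.20 log units; within the scatter). For compound 4, the estimated value is 40000 nM, with an expected range of 12000 nM to 100000 nM.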

Compound 4, concentration for 50% growth inhibition: 29500 nM
Beside the measured number, compound 4's estimate is 1.4-fold (0.13 log units) above it; the measured number falls inside the stated range.
By their numbers in this assay, from the lowest: compound 2; then compound 4; then compounds 3 and 1 (each within the scatter of the next).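

In this assay, the 2,6-dimethoxyphenyl group on a carbon with a double bond to nitrogen gives a lower number than either 4-hydroxyphenyl or phenyl, with a 2.1-fold lower number from compound 3 to compound 4 (0.33 log units; beyond the scatter) and a 2.6-fold lower number from compound 1 to compound 4 (0.41 log units; beyond the scatter), but it does not match 2-hydroxyphenyl, with a 2.2-fold higher number from compound 2 to compound 4 (0.35 log units; beyond the scatter). Among the earlier compounds, only compound 2 stood beyond the scatter from compound 1; compound 4 now does so as well, so a modest gain at this position is no longer tied to a single hydroxy compound. The change also shows that a hydroxy group is not required for such a gain, since 2,6-dimethoxyphenyl has 0 hydrogen-bond donors and 2 hydrogen-bond acceptors.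

Nothing available explains why these groups rank as they do. The compounds shown leave open what a single methoxy group would do on its own, as compound 4 carries two that cannot be separated, and whether an amine or a carboxylic acid on this phenyl ring would reach or pass the number of compound 2.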